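A few compounds are considered here, and "the series" means these few. Any claim that something is new, unique, unknown or untested is made for them only; others in the source may bear on it.

In a functional assay on HT-29 cells (Homo sapiens) for inhibition, read by sulforhodamine B assay, with a stated time of 72 h (a higher number here means a weaker inhibitor, a lower number a stronger inhibitor), compound 1 (`COc1cc2c(Nc3ccc(F)c(Cl)c3)ncnc2cc1OCCOCCn1ccnc1[N+](=O)[O-]`) gives 9860 nM, compound 2 (`C#Cc1cccc(Nc2ncnc3cc(OCCCCn4ccnc4[N+](=O)[O-])c(OC)cc23)c1`) gives 2520 nM, and compound 3 (`C#Cc1cccc(Nc2ncnc3cc(OCCCCCn4ccnc4[N+](=O)[O-])c(OC)cc23)c1`) gives 1310 nM. Compound 3 therefore stands level with compound 2 within the scatter, while its number is lower than that of compound 1 by a margin beyond the scatter.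

The next change leads to compound 4 (`C#Cc1cccc(Nc2ncnc3cc(OCCOCCn4ccnc4[N+](=O)[O-])c(OC)cc23)c1`): 2-(2-nitro-1H-imidazol-1-yl)ethoxy in place of 3-(2-nitro-1H-imidazol-1-yl)propyl on a saturated chain carbon, two bonds along the chain from an oxygen on an aromatic ring. Here 2-(2-nitro-1H-imidazol-1-yl)ethoxy replaces 3-(2-nitro-1H-imidazol-1-yl)propyl.

For the measured compounds named here, the only measured step along the chain is a 1.9-fold lower number from compound 2 to compound 3 (0.28 log units; within the scatter), and it offers no sign of a large shift. Compound 1 carries the same 2-(2-nitro-1H-imidazol-1-yl)ethoxy group and shows 9860 nM, but it also differs from compound 4 elsewhere, so it is only a weak pointer towards a higher number. Going by the values given here, no measured step isolates this exchange. In this assay, a small rise, about the size of the scatter, is therefore expected.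

The expected step is a 1.8-fold higher number from compound 3 to compound 4 (0.26 log units; within the scatter). Compound 4 is estimated at 2400 nM, with an expected range of 1000 nM to 6000 nM.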

Compound 4, half-maximal inhibitory concentration: 8770 nM
Compound 4: the middle estimate sits 3.7-fold (0.56 log units) below what was measured, outside the stated range (above it).
By their numbers in this assay, from the lowest: compounds 3 and 2 (each within the scatter of the next); then compounds 4 and 1 (each within the scatter of the next).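

In this assay, for the compounds shown here, the chain at this place proves sensitive to its make-up: 2-(2-nitro-1H-imidazol-1-yl)ethoxy in place of the all-carbon chain ends gives a 6.7-fold higher number from compound 3 to compound 4 (0.83 log units; beyond the scatter) and a 3.5-fold higher number from compound 2 to compound 4 (0.54 log units; beyond the scatter), whereas the only earlier step along the chain, a 1.9-fold lower number from compound 2 to compound 3 (0.28 log units; within the scatter), stayed within the scatter. The group on the nitrogen shows no such effect with this ether chain: 3-ethynylphenyl in place of 3-chloro-4-fluorophenyl gives a 1.1-fold lower number from compound 1 to compound 4 (0.05 log units; within the scatter), so the two groups cannot be told apart here. Nothing available explains the rise seen with the ether chain.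

Open, on these data alone, is whether an amine in the chain in place of the oxygen would stay with the higher numbers, or whether a longer all-carbon chain would lower the number further. Also open, as far as these compounds go, is whether 3-chloro-4-fluorophenyl would match 3-ethynylphenyl on an all-carbon chain.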